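This account rests on a few compounds, and the source may have more. Where it says the series, first, only, none or still open, it means among the compounds named here.

Measured compounds in a functional assay on SW-620 cells (Homo sapiens) for antiproliferative activity, read by MTT assay, with a stated time of 72 h; on this read-out higher numbers stand for weaker inhibition and lower numbers for stronger inhibition:
Compound 1 `C[Si](C)(C)CCOCn1c(CC(O)COCc2ccccc2)cc(=O)[nH]c1=O` gives > 100000 nM, which is a limit of the assay.
Compound 2 `Cc1c(CC(O)COCc2ccccc2)n(COCC[Si](C)(C)C)c(=O)[nH]c1=O` gives > 100000 nM, which is a limit of the assay.
Compound 3 `C[Si](C)(C)CCOCn1c(CC(O)CO)cc(=O)[nH]c1=O` gives > 100000 nM, which is a limit of the assay.

Compound 3 thus stands at the limit, and no number places it anywhere within the measured range. Among the compounds with values here, the same holds for the other two members, as summed up in the limit of > 100000 nM in this assay, at which 3 of the 3 values shown sit; no compound in this set has yet returned a readable number.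

Compound 4 `Cc1c(CC(O)CO)n(COCC[Si](C)(C)C)c(=O)[nH]c1=O` differs from compound 3 by methyl in place of hydrogen on an aromatic carbon. Within the data shown here, two measured steps bear on it. The identical change, carried out on the benzyl-bearing analogue, is the step from compound 1 to compound 2, giving a step that the two limits leave unreadable from compound 1 to compound 2. The change that links the two sub-series, loss of the benzyl, is the step from compound 1 to compound 3, giving a step that the two limits leave unreadable from compound 1 to compound 3. Neither step has a readable size, so no direction or magnitude can be taken from them. For compound 4 the expected step is estimated as a step that the limit leaves unreadable from compound 3 to compound 4, a step that is expected most likely to leave compound 4 at the limit as well. The estimate for compound 4 in this assay is therefore 200000 nM, with a range from 50000 nM to 1000000 nM, and the expectation is that the assay will again report a limit rather than a number.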

Compound 4, half-maximal inhibitory concentration: > 100000 nM
Compound 4 was reported as a limit (the forecaster's own chance of this, stated with the estimate: 85%); the middle value does not contradict the limit.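

In this assay compound 4 gives > 100000 nM, a limit of the assay. Its steps from compound 2 and compound 3 therefore cannot be read. Whether the methyl or the benzyl changes activity at all remains open, with every compound shown at the same limit: the limit of > 100000 nM in this assay, at which 4 of the 4 values shown sit.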